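Efficacy notes on a shared-core amine series

The source may hold more compounds than are shown below. What is called first, only, known or untested is meant among the compounds shown, and "the series" means these compounds.

Compound 1 `COC[C@H](NC1CCN(CCCc2c[nH]c3ccc(-n4cnnc4)cc23)CC1)c1ccccc1` gives 93% in a functional assay on CHO cells for activation of 5-hydroxytryptamine receptor 1D (Homo sapiens), read by GTPgammaS binding; on this read-out lower numbers stand for smaller maximal responses and higher numbers for larger maximal responses.
Compound 2 `NC(=O)OC[C@H](NC1CCN(CCCc2c[nH]c3ccc(-n4cnnc4)cc23)CC1)c1ccccc1` gives 73% in this assay.

Compound 1 stands highest of the two measured numbers; its nearest neighbour is compound 2, reached by a number 20 percentage points lower from compound 1 to compound 2 (beyond the scatter). Compound 3 `CN(Cc1ccsc1)C1CCN(CCCc2c[nH]c3ccc(-n4cnnc4)cc23)CC1` has not been measured in this assay. It differs from compound 1 by methyl((thiophen-3-yl)methyl)amino in place of (2-methoxy-1-phenylethyl)amino on a saturated ring carbon.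

Among the compounds with values here, only the step from compound 1 to compound 2 bears on this, and only loosely: it altered the same side group at its oxygen and produced a number 20 percentage points lower from compound 1 to compound 2 (beyond the scatter), a modest shift beyond the scatter. The change to compound 3 exchanges the whole side group, so a step at least as large is expected, most likely downward, with wide uncertainty in the absence of any closer comparison. The expected step is a number 18 percentage points lower from compound 1 to compound 3 (beyond the scatter). For compound 3 the efficacy in this assay is estimated at 75%, in the range 45% to 100%.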

Compound 3, largest response reached (reported as efficacy), in percent of the reference or control that the assay uses: 93%
Compound 3: the middle estimate sits 18 percentage points below what was measured; the range from low to high includes it.
By their numbers in this assay, from the lowest: compound 2; then compounds 1 and 3 (each within the scatter of the next).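

In this assay, the side group on the saturated ring carbon can be exchanged whole with no change at the digits printed from compound 1 to compound 3 (within the scatter), so the methyl((thiophen-3-yl)methyl)amino group serves as well as (2-methoxy-1-phenylethyl)amino for the maximal response. In this pair, the six-membered aromatic ring of carbon only, the defined stereocentre and the hydrogen-bond donor of the leaving group are therefore not needed for that response, and the change at the oxygen, with a number 20 percentage points lower from compound 1 to compound 2 (beyond the scatter), does not mark every change in this side group as costly. No supporting data are available to account for this result.

From the compounds shown here alone, it remains open whether the thiophen-3-yl ring or the methyl on the amine matters here. A benzyl(methyl)amino or a plain dimethylamino group in the same place would separate these two parts.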